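A Chloro Substituent Added to a Limit-Bound Compound

The compounds below may be only part of what the source reports. "The series", "measured", "known", "first", "only" and "open" are said of these compounds alone.

Compound 1, `O=c1cc(CSc2nc3ccccc3s2)oc2ccccc12`: in a functional assay on SW480 cells (Homo sapiens) for cytotoxicity, read by MTT assay, with a stated time of 72 h (a higher number here means a weaker inhibitor, a lower number a stronger inhibitor), compound 1 gives > 25000 nM, which is a limit of the assay rather than a number.
Compound 2, `Cc1nnc(Sc2coc3ccccc3c2=O)s1`: compound 2 gives > 50000 nM, again a limit.
Compound 3, `Cc1nnc(SCc2coc3ccc(Cl)cc3c2=O)o1`: compound 3 gives 3500 nM.

Of the three values, two are limits, and compound 1 is one of them: it sits at the limit of > 25000 nM in this assay, at which 1 of the 3 values shown sits, while compound 2 sits at the limit of > 50000 nM in this assay, at which 1 of the 3 values shown sits. Going by the values given here, only compound 3 gives a measurable number, and it is the one compound of the three that carries a chloro group on its shared core.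

Compound 4, `O=c1cc(CSc2nc3ccccc3s2)oc2ccc(Cl)cc12`, has not been measured in this assay. It differs from compound 1 by chloro in place of hydrogen on an aromatic carbon. Among the compounds with values here, no measured pair isolates this same change, so its size cannot be read from the data. What can be said is that compound 1 sits at a limit and compound 3, which also bears a chloro, gives a number. On that basis the step from compound 1 to compound 4 is expected to run toward stronger inhibition, with an at least 2.5-fold lower number from compound 1 to compound 4 (0.39 log units; beyond the scatter) as the estimate of its size. For compound 4 in this assay the expected value is 10000 nM, within a range from 3000 nM to 40000 nM.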

Compound 4, half-maximal inhibitory concentration: > 25000 nM
Compound 4 ended at the assay's limit; the forecaster's own chance of this, stated with the estimate: 40%; at least 2.5-fold (0.39 log units) between middle value and limit.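

Compound 1 and compound 4 both end at the same limit of the assay, so no step between them can be read: the limit of > 25000 nM in this assay, at which 2 of the 4 values shown sit.

The compounds shown leave open whether chloro in place of hydrogen on an aromatic carbon changes the strength of inhibition on the core of compound 1 in this assay at all.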